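A few compounds are considered here, and "the series" means these few. Any claim that something is new, unique, unknown or untested is made for them only; others in the source may bear on it.

Compound 3, `C=CCc1cc(O)cc2c1OC(c1ccc(O)cc1)CC2=O`, gives the largest maximal response of the three measured compounds in a functional assay on aorta (Rattus norvegicus, strain Sprague-Dawley) for inhibition, with a stated time of 20 min (on this read-out lower numbers stand for smaller maximal responses and higher numbers for larger maximal responses), at 95.3%. The nearest measured compound is compound 1, `C=CCc1c(O)cc(O)c2c1OC(c1cccc(Cl)c1)CC2=O`, which in this assay gives 76.7%; compound 2, `C=CCc1c(O)cc(O)c2c1OC(c1ccc(O)cc1)CC2=O`, lies furthest away with 9.86% in this assay.

Compound 4, `C=CCc1cc(O)cc2c1OC(c1cccc(O)c1)CC2=O`, differs from compound 3 by 3-hydroxyphenyl in place of 4-hydroxyphenyl on a saturated ring carbon. Within the data shown here, only one measured step concerns the group on this saturated ring carbon, a number 66.8 percentage points lower from compound 1 to compound 2 (beyond the scatter), and it exchanges 3-chlorophenyl for 4-hydroxyphenyl, not one hydroxyphenyl for another. Compounds 1 and 3 differ in two places at once, so their values alone show that a 3-substituted phenyl and a 4-hydroxyphenyl both sit well above compound 2. Among the measured compounds shown here, no measured pair isolates a move of the hydroxyl from the 4-position to the 3-position on this phenyl.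

For the measured compounds named here, with no direct precedent, the step is expected to be small to moderate, more likely downward than upward given that compound 3 already stands at the top of the measured range, and it is estimated as a number 15.3 percentage points lower from compound 3 to compound 4 (beyond the scatter). Compound 4 is therefore expected to give about 80% in this assay, within a range from 50% to 100%.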

Compound 4, largest response reached (Emax), in percent of the reference or control that the assay uses: 90.2%
Beside the measured number, compound 4's estimate is 10.2 percentage points below it; the measured number falls inside the stated range.
By their numbers in this assay, from the lowest: compound 2; then compound 1; then compounds 4 and 3 (each within the scatter of the next).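

In this assay, exchanging 4-hydroxyphenyl for 3-hydroxyphenyl on the saturated ring carbon next to the ring oxygen gives a number 5.1 percentage points lower from compound 3 to compound 4 (within the scatter), so on the core shared by these two compounds the read-out does not separate the two placements of the hydroxyl. Among these compounds, this is the first pair in which only the placement of that hydroxyl changes, whereas the one earlier step at this carbon, a number 66.8 percentage points lower from compound 1 to compound 2 (beyond the scatter), exchanged 3-chlorophenyl for 4-hydroxyphenyl on a different core, and the present step is far smaller in size. No available evidence explains why the placement of the hydroxyl leaves the read-out within the scatter here.

The compounds shown leave open whether 3-hydroxyphenyl and 4-hydroxyphenyl would also stay within the scatter of each other on the core of compound 2, which gives a much smaller maximal response than compound 3 or compound 4. They also leave open what would follow if a methoxy group, an amine or a carboxylic acid took the place of the hydroxyl on this phenyl ring.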